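Swapping hydroxy for methoxy on a nitro-bearing ester

The source may hold more compounds than are shown below. What is called first, only, known or untested is meant among the compounds shown, and "the series" means these compounds.

Compound 1 `CC1(C)C2CCC1(C)C(OC(=O)/C=C/c1ccc(O)c(O)c1[N+](=O)[O-])C2`: 28700 nM
Compound 2 `CC1(C)C2CCC1(C)C(OC(=O)/C=C/c1ccc(O)c(O)c1)C2`: 28200 nM

Among the compounds with values here, in a functional assay on Bel-7402 cells (Homo sapiens) for cytotoxicity, read by MTT assay (on this read-out lower numbers stand for stronger inhibition and higher numbers for weaker inhibition), compound 1 stands level with the only other measured compound. Within the data shown here, the single measured step, a 1.0-fold lower number from compound 1 to compound 2 (0.01 log units; within the scatter), puts hydrogen in place of nitro and stays within the scatter. Compound 3 `COc1c(O)ccc(/C=C/C(=O)OC2CC3CCC2(C)C3(C)C)c1[N+](=O)[O-]` differs from compound 1 elsewhere: methyl in place of hydrogen on an oxygen on an aromatic ring, with methyl in place of hydrogen on an oxygen on an aromatic ring, or hydroxy to methoxy. Among the measured compounds shown here, no measured step tests this change, so no shift beyond the scatter is expected in this assay, in either direction. The expected step is a 1.0-fold lower number from compound 1 to compound 3 (0.01 log units; within the scatter). For compound 3 the estimated value is 28000 nM, within an expected range of 13000 nM to 60000 nM.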

Compound 3, half-maximal inhibitory concentration: 6600 nM
The estimate for compound 3 lay 4.2-fold (0.63 log units) above the measured number; the whole stated range lies above it.
By their numbers in this assay, from the lowest: compound 3; then compounds 2 and 1 (each within the scatter of the next).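

Putting methyl on an oxygen on an aromatic ring, hydroxy to methoxy, gives the first shift beyond the scatter in this assay (a 4.3-fold lower number from compound 1 to compound 3 (0.64 log units; beyond the scatter)). The earlier step, hydrogen in place of nitro (a 1.0-fold lower number from compound 1 to compound 2 (0.01 log units; within the scatter)), stayed within the scatter, so this oxygen affects the read-out in a way the nitro change did not show. Nothing available explains the shift.

On these data alone, it remains open whether the same change gives a similar shift without the nitro group. Also open, as far as these compounds go, is whether a longer chain, such as ethoxy, or an amine in place of methoxy would lower the number further.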